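Cytotoxicity shift on changing the triazole-bound side chain

The source may hold more compounds than are shown below. What is called first, only, known or untested is meant among the compounds shown, and "the series" means these compounds.

Measured compounds:
compound 1, `COC(=O)Cn1cc(CNC(=O)c2cnc(Nc3ccc(C#N)cc3)cc2Oc2c(C)cc(C)cc2C)nn1`, 13800 nM in an ADME assay on MT4 cells (Homo sapiens) for cytotoxicity, read by MTT assay, with a stated time of 5 days; a lower number here means that less compound is tolerated, a higher number that more compound is tolerated
compound 2, `Cc1cc(C)c(Oc2cc(Nc3ccc(C#N)cc3)ncc2C(=O)NCc2cn(Cc3ccc(Cl)cc3)nn2)c(C)c1`, >= 120000 nM in this assay

Compound 2 sits at the limit of this assay, so only a bound is known for it; (the limit of >= 120000 nM in this assay, at which 1 of the 2 values shown sits). Compound 3, `Cc1cc(C)c(Oc2cc(Nc3ccc(C#N)cc3)ncc2C(=O)NCc2cn(CC(=O)N3CCOCC3)nn2)c(C)c1`, is the next compound, carrying the change ((morpholin-4-yl)carbonyl in place of 4-chlorophenyl on a saturated chain carbon bound to an aromatic nitrogen), that is, 4-chlorobenzyl to ((morpholin-4-yl)carbonyl)methyl. Among the compounds with values here, the one measured step at this position, an at least 8.6-fold higher number from compound 1 to compound 2 (0.93 log units; beyond the scatter), went from a methoxycarbonyl, a carbonyl-bearing chain, to the 4-chlorophenyl; compound 3 brings a carbonyl-bearing chain back, so a step downward from compound 2, toward compound 1, is expected, though its size is uncertain since compound 2 is only a bound. Compound 3 is therefore expected to give 40000 nM in this assay, between 12000 nM and 120000 nM, which amounts to an estimated at least 3.0-fold lower number from compound 2 to compound 3 (0.47 log units; beyond the scatter).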

Compound 3, half-maximal cytotoxic concentration: 181000 nM
Beside the measured number, compound 3's estimate is 4.5-fold (0.66 log units) below it; the whole stated range lies below it.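

A carbonyl on the saturated chain carbon bound to an aromatic nitrogen does not by itself keep the number low: morpholin-4-yl in place of methoxy on that carbonyl carbon gives a 13-fold higher number from compound 1 to compound 3 (1.12 log units; beyond the scatter). Among the three compounds, the low number therefore stays with the methoxycarbonyl of compound 1, and compound 3 goes against any reading based on the carbonyl-bearing chain alone. Compound 2 remains a limit in this assay, and its step to compound 3 cannot be read: the limit of >= 120000 nM in this assay, at which 1 of the 3 values shown sits.

Open, on these data alone, is whether the shift follows the morpholine ring or simply the replacement of the methoxy on the carbonyl carbon. A piperidin-1-yl or dimethylamino group on that carbonyl, or a free carboxylic acid in place of the methoxycarbonyl, would bear on this question.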